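Amide Nitrogen Exchange on a Cinnamamide-Type Side Chain

The source may hold more compounds than are shown below. What is called first, only, known or untested is meant among the compounds shown, and "the series" means these compounds.

Compound 1, `O=C(CCc1ccc(NC(=O)Nc2ccc(Cl)c(C(F)(F)F)c2)cc1)NC1CCC1`, gives > 50000 nM in a functional assay on A-375 cells (Homo sapiens) for inhibition, read by MTT assay, with a stated time of 120 h; on this read-out higher numbers stand for weaker inhibition and lower numbers for stronger inhibition; this is a limit of the assay, not a number.
Compound 2, `O=C(/C=C/c1ccc(NC(=O)Nc2ccc(Cl)c(C(F)(F)F)c2)cc1)NC1CCC1`, gives 15400 nM in this assay.
Compound 3, `CNC(=O)/C=C/c1ccc(NC(=O)Nc2ccc(Cl)c(C(F)(F)F)c2)cc1`, gives 20900 nM in this assay.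

Among the numbers shown, compound 3 holds the highest of the two; its nearest neighbour is compound 2, and the step of a 1.4-fold higher number from compound 2 to compound 3 (0.13 log units; within the scatter) lies within the scatter. Compound 4, `CC1CN(C(=O)/C=C/c2ccc(NC(=O)Nc3ccc(Cl)c(C(F)(F)F)c3)cc2)CC(C)O1`, differs from compound 3 in one place: 2,6-dimethylmorpholin-4-yl in place of methylamino on a carbonyl carbon. Going by the values given here, only one measured step touches this amide-type nitrogen, the exchange a 1.4-fold higher number from compound 2 to compound 3 (0.13 log units; within the scatter), which stays within the scatter. The steps of an at least 3.2-fold lower number from compound 1 to compound 2 (0.51 log units; beyond the scatter) and an at least 2.3-fold lower number from compound 1 to compound 3 (0.37 log units; beyond the scatter) concern the ethenyl in place of the ethyl and do not bear on the amide nitrogen; compound 4 keeps the ethenyl of compound 3. The step to compound 4 in this assay is therefore expected to be small, a 1.3-fold lower number from compound 3 to compound 4 (0.12 log units; within the scatter), with no direction beyond the scatter firmly indicated. Compound 4 is estimated at 16000 nM, between 5000 nM and 50000 nM.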

Compound 4, half-maximal inhibitory concentration: > 50000 nM
Compound 4 gave a limit, no number; the forecaster's own chance of this, stated with the estimate: 15%; middle value at least 3.1-fold (0.49 log units) away from the limit.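

The group on the carbonyl carbon turns out not to be indifferent: cyclobutylamino and methylamino had stayed close, with a 1.4-fold higher number from compound 2 to compound 3 (0.13 log units; within the scatter), whereas 2,6-dimethylmorpholin-4-yl, which carries no amide hydrogen, gives an at least 2.3-fold higher number from compound 3 to compound 4 (0.37 log units; beyond the scatter) and an at least 3.2-fold higher number from compound 2 to compound 4 (0.51 log units; beyond the scatter). In this assay compound 4 gives > 50000 nM, which is a limit of the assay and not a number, and both new steps are bounded on one side only. Compound 4 keeps the ethenyl of compound 2 and compound 3, yet the ethenyl alone does not keep the value off the limit: the limit of > 50000 nM in this assay, at which 2 of the 4 values shown sit.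

The ring, its two methyl groups and the missing amide hydrogen all change together in compound 4, and the compounds shown do not separate them. Going by these compounds, it stays open whether unsubstituted morpholine, piperidine or dimethylamino on the same carbonyl carbon would also reach the limit.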